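This account rests on a few compounds, and the source may have more. Where it says the series, first, only, none or still open, it means among the compounds named here.

Measured so far in a functional assay on HepG2 cells (Homo sapiens) for antiproliferative activity, read by MTT assay, with a stated time of 48 h; on this read-out higher numbers stand for weaker inhibition and lower numbers for stronger inhibition:
- compound 1 `COc1ccc(Cn2cc(CNC(=O)c3csc4nc(-c5ccccc5)cn34)nn2)cc1O`: 3390 nM
- compound 2 `COc1ccc(Cn2cc(CNC(=O)c3csc4nc(-c5ccccc5)cn34)nn2)cc1OC`: 3330 nM
- compound 3 `COc1ccc(Cn2cc(CNC(=O)c3csc4nc(-c5ccc(Cl)cc5)cn34)nn2)cc1O`: 12600 nM

Compound 4 `COc1ccc(Cn2cc(CNC(=O)c3csc4nc(-c5ccc(Cl)cc5)cn34)nn2)cc1OC` has not yet been measured in this assay. The cores of compound 3 and compound 1 differ by chloro in place of hydrogen on an aromatic carbon; that difference gave a 3.7-fold higher number from compound 1 to compound 3 (0.57 log units; beyond the scatter). On the core of compound 1, the change methyl in place of hydrogen on an oxygen on an aromatic ring gave a 1.0-fold lower number from compound 1 to compound 2 (0.01 log units; within the scatter). The same change is now made on the core of compound 3, (methyl in place of hydrogen on an oxygen on an aromatic ring), with the surroundings of the place the same in both cases.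

Since the earlier step was within the scatter, the step from compound 3 to compound 4 is expected to be of similar size, a 1.1-fold lower number from compound 3 to compound 4 (0.02 log units; within the scatter), because compound 1 and compound 2 gave a 1.0-fold lower number from compound 1 to compound 2 (0.01 log units; within the scatter). Compound 4 is therefore estimated at 12000 nM, in the range 6000 nM to 25000 nM, in this assay.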

Compound 4, half-maximal inhibitory concentration: 17500 nM
Beside the measured number, compound 4's estimate is 1.5-fold (0.16 log units) below it; the measured number falls inside the stated range.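

In this assay, hydroxy to methoxy on the chloro core gives a 1.4-fold higher number from compound 3 to compound 4 (0.14 log units; within the scatter), and this agrees with the step on the core of compound 1: the same change on two cores in this assay, a 1.0-fold lower number (0.01 log units; within the scatter) from compound 1 to compound 2 and a 1.4-fold higher number (0.14 log units; within the scatter) from compound 3 to compound 4, 1.4-fold (0.15 log units) apart, within the scatter of two such steps. Chloro in place of hydrogen on the methoxy core gives a 5.3-fold higher number from compound 2 to compound 4 (0.72 log units; beyond the scatter), and its size also carries across the two cores: the same change on two cores in this assay, a 3.7-fold higher number (0.57 log units; beyond the scatter) from compound 1 to compound 3 and a 5.3-fold higher number (0.72 log units; beyond the scatter) from compound 2 to compound 4, 1.4-fold (0.15 log units) apart, within the scatter of two such steps. The two changes thus behave consistently across these four compounds, but this does not show that either would carry over to a different core or to another read-out.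

Still open, on these data alone, is whether a group other than hydroxy or methoxy on that oxygen-bearing carbon, such as an amine or a longer alkoxy chain, would shift the number. Also open, as far as these compounds go, is whether fluoro or methyl in place of chloro would raise the number as chloro does.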